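A few compounds are considered here, and "the series" means these few. Any claim that something is new, unique, unknown or untested is made for them only; others in the source may bear on it.

Three compounds of a shared sulfonyl-urea type were measured in an assay on isolated protein for displacement of a labelled ligand from Orexin/Hypocretin receptor type 1 (Homo sapiens), with a stated time of 90 min; a lower number here means a stronger inhibitor, a higher number a weaker inhibitor. Compound 1 `COc1cc(F)c(CN2C(=O)N(c3ccc(OC)c(OC)c3)S(=O)(=O)c3ccccc32)c(Cl)c1` gives 0.398 nM. Compound 2 `COc1ccc(N2C(=O)N(Cc3c(F)cccc3Cl)c3ccccc3S2(=O)=O)cc1OC` differs from it by hydrogen in place of methoxy on an aromatic carbon, and in this assay compound 2 gives 7.94 nM, a step of a 20-fold higher number from compound 1 to compound 2 (1.30 log units; beyond the scatter). Compound 3 `COc1cc(N2C(=O)N(Cc3c(F)cc(F)cc3F)c3ccccc3S2(=O)=O)cc(OC)n1` carries a different benzyl group and a ring with one nitrogen in place of the dimethoxyphenyl; the difference between the cores of compound 1 and compound 3 is not broken down here. In this assay compound 3 gives 15.9 nM. Compound 4 `COc1cc(N2C(=O)N(Cc3c(F)cc(F)cc3F)c3ccccc3S2(=O)=O)ccn1`, not yet measured, differs from compound 3 by hydrogen in place of methoxy on an aromatic carbon. This is the same kind of change as that from compound 1 to compound 2, yet the place differs: there on a ring of carbon only, meta to a chloro group and a fluoro group, para to a large group; here on a six-membered ring with one nitrogen, next to the ring nitrogen, meta to a large group and to a methoxy group. Because the measured step of a 20-fold higher number from compound 1 to compound 2 (1.30 log units; beyond the scatter) was large, but sits in different surroundings, a smaller weakening is expected for compound 4, a step of a 3.1-fold higher number from compound 3 to compound 4 (0.50 log units; beyond the scatter). Compound 4 is therefore estimated at 50 nM, with a range from 15 nM to 200 nM.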

Compound 4, inhibition constant: 398 nM
Compound 4: the middle estimate sits 8.0-fold (0.90 log units) below what was measured, outside the stated range (above it).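

In this assay, going from 2,6-dimethoxypyridin-4-yl to 2-methoxypyridin-4-yl gives a 25-fold higher number from compound 3 to compound 4 (1.40 log units; beyond the scatter), a large weakening. Set beside the earlier step, hydrogen in place of methoxy costs about the same on both cores, even though the ring and the surroundings differ: the same change on two cores in this assay, a 20-fold higher number (1.30 log units; beyond the scatter) from compound 1 to compound 2 and a 25-fold higher number (1.40 log units; beyond the scatter) from compound 3 to compound 4, 1.3-fold (0.10 log units) apart, within the scatter of two such steps. So the size of this change carried over between these two cores, but two pairs make no rule for the whole series, and they do not explain why the methoxy group matters.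

The compounds shown leave open whether the step would hold on a third core. They also leave open how other groups in the place of the methoxy group, such as an ethoxy group or an amine, would compare.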